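The compounds below may be only part of what the source reports. "The series", "measured", "known", "first", "only" and "open" are said of these compounds alone.

Measured compounds:
Compound 1 `CC/C(=C(/c1ccc(/C=C/C(=O)O)cc1)c1ccn2nncc2c1)c1ccccc1`: > 500 nM (a limit of the assay, not a number)
Compound 2 `CC/C(=C(/c1ccc(/C=C/C(=O)O)cc1)c1ccc(-c2cncs2)cc1)c1ccccc1`: 31 nM

Going by the values given here, in a functional assay on MCF7 cells (Homo sapiens) for antiproliferative activity, read by CellTiter-Glo, with a stated time of 5 days (on this read-out lower numbers stand for stronger inhibition and higher numbers for weaker inhibition), compound 2 gives 31 nM, the only true number available so far. Compound 1 gives only a limit, > 500 nM. Among the compounds with values here, the position of compound 2 therefore rests on very little, and no measured step between similar compounds is available as a guide.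

The next compound, compound 3 `CC/C(=C(/c1ccc(/C=C/C(=O)O)cc1)c1ccc(-c2cc[nH]n2)cc1)c1ccccc1`, keeps the shared core of compound 2 and changes one group. It carries 1H-pyrazol-3-yl in place of 1,3-thiazol-5-yl on an aromatic carbon, para to a large group: 1H-pyrazol-3-yl in place of 1,3-thiazol-5-yl on an aromatic carbon.

With no measured swap of this kind to draw on, the expectation in this assay is for little or no change beyond the usual scatter, with a slight lean towards weaker inhibition. The estimated step is a 1.3-fold higher number from compound 2 to compound 3 (0.11 log units; within the scatter). This expectation starts from compound 2 at 31 nM, and the wide range reflects how little has been measured. The expected value for compound 3 is 40 nM, with an estimated range from 12 nM to 150 nM.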

Compound 3, half-maximal inhibitory concentration: 440 nM
For compound 3 the middle estimate is 11-fold (1.04 log units) below the measured one; measured number outside the range, above it.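

This position is far from indifferent to which five-membered ring it carries. In this assay the change from 1,3-thiazol-5-yl to 1H-pyrazol-3-yl gives a 14-fold higher number from compound 2 to compound 3 (1.15 log units; beyond the scatter) and that is a large step for two groups with the same number of heavy atoms, each a five-membered aromatic ring with 2 hetero atoms; the counts differ only in a nitrogen taking the place of sulfur and in the gain of a hydrogen-bond donor with the loss of an acceptor. Compound 3 also lands close to the top of what this read-out reports as a number, so little room remains to follow any further weakening in this series: the limit of > 500 nM in this assay, at which 1 of the 3 values shown sits.

On these data alone, whether the loss travels with the hydrogen-bond donor or with the departure of sulfur stays open, since a single pair cannot separate the two. A pyrazole carrying a methyl group on its ring nitrogen, or a thiophene ring in the same place, would help to pull these two apart.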